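The compounds below may be only part of what the source reports. "The series", "measured", "known", "first", "only" and "open" are said of these compounds alone.

Compound 1 `COc1ccc(C2N=C(SCc3ccccc3Cl)NC(C)=C2C(=O)Nc2ccc(F)cc2)cc1OC` was tested in a functional assay on the whole organism (artery, strain albino) with Rattus norvegicus as the target, with a stated time of 120 min, at a dose of 10 mg/kg by the oral route (a lower number here means less inhibition, a higher number more inhibition at the dose given (going by the name of the read-out)), and in that test compound 1 gives 17%. Compound 2 `COc1ccc(C2N=C(SCc3cccc(Cl)c3)NC(C)=C2C(=O)Nc2ccc(F)cc2)cc1OC` differs from compound 1 only by 3-chlorophenyl in place of 2-chlorophenyl on a saturated chain carbon bound to a sulfur; in this assay compound 2 gives 10.8%, a step of a number 6.2 percentage points lower from compound 1 to compound 2 (within the scatter). Compound 3 `CC1=C(C(=O)Nc2ccc(Br)cc2)C(c2ccc(Cl)cc2Cl)N=C(SCc2ccccc2Cl)N1` is built on a different core; the difference between the two cores is not broken down here. In this assay compound 3 gives 16%, which is within the scatter of the values of compound 1 and compound 2. Compound 4 `CC1=C(C(=O)Nc2ccc(Br)cc2)C(c2ccc(Cl)cc2Cl)N=C(SCc2cccc(Cl)c2)N1` applies the same change to the core of compound 3: 3-chlorophenyl in place of 2-chlorophenyl on a saturated chain carbon bound to a sulfur. Because the step of a number 6.2 percentage points lower from compound 1 to compound 2 (within the scatter) stayed within the scatter, a similarly small step is expected from compound 3 to compound 4, estimated as a number 5 percentage points lower from compound 3 to compound 4 (within the scatter). Compound 4 is therefore expected to give about 11% in this assay, most likely between 0% and 24%.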

Compound 4, a percentage reported as inhibition, in the whole organism at one dose (the size of the read-out at that dose, not a potency): 8.8%
For compound 4 the middle estimate is 2.2 percentage points above the measured one; measured number inside the range.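

In this assay, putting 3-chlorophenyl in place of 2-chlorophenyl on a saturated chain carbon bound to a sulfur gives a number 7.2 percentage points lower from compound 3 to compound 4 (within the scatter). Set beside the earlier case, the change behaves alike on the two cores: the same change on two cores in this assay, a number 6.2 percentage points lower (within the scatter) from compound 1 to compound 2 and a number 7.2 percentage points lower (within the scatter) from compound 3 to compound 4, 1 percentage points apart, within the scatter of two such steps. Each step on its own lies within the scatter, and two cores are only two cases, so this does not show that the change truly lowers the inhibition, or that it would hold on a further core.

The compounds shown leave open what an amine or a carboxylic acid in place of the chlorine, or a longer chain in place of the benzyl group, would give. They also leave open how these compounds compare at other doses.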